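Dichlorophenyl Ether Variant on the Shared Core

The source may report more compounds than this note shows. Statements on the series, on what has been measured and on what is new or still open speak of the compounds shown alone.

The series keeps one core and varies the aryl ether at the end of the chain on the ring nitrogen. Compound 1 is `NC1=NC2(CCOCC2)N(OCCCOc2ccccc2)C(N)=N1`. Compound 2 is `NC1=NC2(CCSCC2)N(OCCCOc2cccc(Cl)c2)C(N)=N1`. Compound 3, not yet tested, is `NC1=NC2(CCOCC2)N(OCCCOc2ccc(Cl)cc2Cl)C(N)=N1`.

In an assay on isolated protein for inhibition of Dihydrofolate reductase (Homo sapiens), read by spectrophotometry, using NADPH, with stated times of 5 s and 6 min, tested at 5 uM (a lower number here means a weaker effect, a higher number a stronger effect of the compound at the concentration tested), compound 1 gives > 90%. This value is a limit of the assay rather than a number, as noted in the record (the limit of > 90% in this assay, at which 1 of the 2 values shown sits). In this assay compound 2 gives 88.3%. The two values sit within the usual scatter of each other, so no order between compound 1 and compound 2 can be read from them.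

Compound 3 differs from compound 1 in a single place: 2,4-dichlorophenyl in place of phenyl on an oxygen on a saturated carbon. Among the measured compounds shown here, no measured pair covers this change. Because compound 1 gives > 90% in this assay, which is a limit, the step from compound 1 to compound 3 is expected to be small, a number no higher from compound 1 to compound 3 (the limit leaves the size open), and not beyond the scatter in either direction. For compound 3 the expected inhibition in this assay is 90%, within a range from 75% to 98%.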

Compound 3, a percentage reported as inhibition, at one concentration (the size of the read-out at that concentration, not a potency): > 90%
Compound 3: only a limit was reported; the forecaster's own chance of this, stated with the estimate: 50%; the middle value sits exactly at the limit.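

Compound 1 and compound 3 both stand at a limit of the assay in this assay, so no step can be read between them: the limit of > 90% in this assay, at which 2 of the 3 values shown sit.

The compounds shown leave open whether 2,4-dichlorophenyl in place of phenyl changes inhibition in this assay at all, and how compound 1 and compound 3 would order beyond that limit.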